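The compounds below may be only part of what the source reports. "The series", "measured", "known", "first", "only" and "open" are said of these compounds alone.

Measured so far in an ADME assay on THP-1 cells (Homo sapiens) for cytotoxicity; a higher number here means a weaker inhibitor, a lower number a stronger inhibitor:
- compound 1 `COc1ccccc1-c1nnc(-c2ccc(C(=O)N/N=C/c3ccc([N+](=O)[O-])cc3)cc2)o1`: 203000 nM
- compound 2 `COc1ccccc1-c1nnc(-c2ccc(C(=O)N/N=C/c3ccccn3)cc2)o1`: 67000 nM
- compound 3 `COc1ccccc1-c1nnc(-c2ccc(C(=O)N/N=C/c3cccc(O)c3O)cc2)o1`: 102000 nM

Compound 3 has the second highest of the three numbers in this assay. Its nearest neighbour is compound 2, with a 1.5-fold higher number from compound 2 to compound 3 (0.18 log units; within the scatter); its furthest is compound 1, with a 2.0-fold lower number from compound 1 to compound 3 (0.30 log units; within the scatter). Compound 4 `COc1ccccc1-c1nnc(-c2ccc(C(=O)N/N=C/c3cccc(F)c3)cc2)o1` differs from compound 3 in one place: 3-fluorophenyl in place of 2,3-dihydroxyphenyl on a carbon with a double bond to nitrogen. All three measured steps swap the group on that same carbon, and only a 3.0-fold lower number from compound 1 to compound 2 (0.48 log units; beyond the scatter) reaches beyond the scatter, and modestly. So a small step, likely within the scatter, is expected in this assay, in no clear direction. The expected step is a 1.0-fold lower number from compound 3 to compound 4 (0.01 log units; within the scatter). Compound 4 is therefore estimated at 100000 nM, with a range from 40000 nM to 250000 nM.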

Compound 4, half-maximal inhibitory concentration: 353000 nM
Compound 4: the middle estimate sits 3.5-fold (0.55 log units) below what was measured, and the stated range ends below it.
By their numbers in this assay, from the lowest: compounds 2, 3, 1 and 4 (each within the scatter of the next, the first and the last beyond it).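

In this assay, the group on the carbon with a double bond to nitrogen now shows more than one step beyond the scatter: 3-fluorophenyl gives a 3.5-fold higher number from compound 3 to compound 4 (0.54 log units; beyond the scatter) and a 5.3-fold higher number from compound 2 to compound 4 (0.72 log units; beyond the scatter), both modest, whereas a 1.7-fold higher number from compound 1 to compound 4 (0.24 log units; within the scatter) does not separate it from 4-nitrophenyl. Among the compounds shown here, earlier, only one pair of groups at this position was separated beyond the scatter. Nothing available explains these steps.

As far as these compounds go, how an amine or a carboxylic acid at this position would read remains open, as does the reading for an unsubstituted phenyl.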